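A few compounds are considered here, and "the series" means these few. Any claim that something is new, unique, unknown or untested is made for them only; others in the source may bear on it.

Series of three measured aryl-alkynyl propanoic acids plus one unmeasured analogue. Compound 2 `O=C(O)CCc1ccc(C#Cc2ccnc(-c3ccccc3)c2)cc1` gives 186 nM in an in vitro functional assay on 1321-N1 cells for agonist activity at Free fatty acid receptor 1 (Homo sapiens), read by fluorescence, spectrophotometry and calcium flux; on this read-out lower numbers stand for an effect already at smaller amounts and higher numbers for an effect only at larger amounts of compound. Compound 1 `Cc1ccccc1-c1cc(C#Cc2ccc(CCC(=O)O)cc2)ccn1` carries the change methyl in place of hydrogen on an aromatic carbon and gives 1070 nM in this assay, so a 5.8-fold higher number from compound 2 to compound 1 (0.76 log units; beyond the scatter). Compound 3 `O=C(O)CCc1ccc(C#Cc2ccnc(Cl)n2)cc1` gives 9120 nM in this assay; the difference between its core and the core of compound 2 is not broken down here. Compound 4 `Cc1cnc(Cl)nc1C#Cc1ccc(CCC(=O)O)cc1` carries methyl in place of hydrogen on an aromatic carbon on the core of compound 3. This is the same kind of change as in compound 1, but the place differs: here the ring has 2 nitrogen and the carbon is para to a chloro group and two atoms from the ring nitrogen, while in compound 1 the ring is of carbon only. Resting on the step from compound 2 to compound 1, compound 4 is expected to show a 2.7-fold higher number from compound 3 to compound 4 (0.44 log units; beyond the scatter) in this assay. For compound 4 the estimate is therefore 25000 nM, with a range of 8000 nM to 80000 nM.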

Compound 4, half-maximal effective concentration: 4270 nM
For compound 4 the middle estimate is 5.9-fold (0.77 log units) above the measured one, outside the stated range (below it).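

Methyl in place of hydrogen on an aromatic carbon gives a 2.1-fold lower number from compound 3 to compound 4 (0.33 log units; beyond the scatter) in this assay. The step seen on one core therefore does not carry over to the other, in size or in direction: the same change on two cores in this assay, a 5.8-fold higher number (0.76 log units; beyond the scatter) from compound 2 to compound 1 and a 2.1-fold lower number (0.33 log units; beyond the scatter) from compound 3 to compound 4, 12-fold (1.09 log units) apart, beyond the scatter of two such steps. This rests on a single pair per core, and the methyl sits at a different place on a different ring in each pair, so the data do not separate the place of the methyl from the core around it and do not show why the steps differ.

Open, as far as these compounds go, is whether ethyl or methoxy in place of that methyl on the core of compound 3 shifts the number the same way. Among the compounds shown here, also open is whether methyl at other carbons of the core of compound 2 follows the step seen for compound 1 or the one seen for compound 4.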